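This account rests on a few compounds, and the source may have more. Where it says the series, first, only, none or still open, it means among the compounds named here.

The series shares one core, seen in compound 1 `CCCCCCCCNc1nc(SCc2ccc(C(F)(F)F)cc2)nc2ccccc12`. Among the measured compounds shown here, in a functional assay on MCF7 cells (Homo sapiens) for cytotoxicity, read by MTT assay, with a stated time of 72 h (on this read-out higher numbers stand for weaker inhibition and lower numbers for stronger inhibition), compound 1 gives 26100 nM, the only number recorded here. The two other values are limits and are given below with their compounds. Compound 2 `FC(F)(F)c1ccc(CSc2nc(N3CCCCC3)c3ccccc3n2)cc1` carries piperidin-1-yl in place of octylamino on an aromatic carbon, and in this assay compound 2 returns only the limit > 50000 nM. Compound 3 `COc1ccccc1Nc1nc(SCc2ccc(C(F)(F)F)cc2)nc2ccccc12` carries 2-methoxyphenyl in place of octyl on a nitrogen on an aromatic ring, and in this assay compound 3 likewise returns only the limit > 50000 nM. The steps read an at least 1.9-fold higher number from compound 1 to compound 2 (0.28 log units; that floor lies within the scatter) and an at least 1.9-fold higher number from compound 1 to compound 3 (0.28 log units; that floor lies within the scatter), while the step that the two limits leave unreadable from compound 2 to compound 3, both ends sitting at the limit of > 50000 nM in this assay, at which 2 of the 3 values shown sit.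

Compound 4 `COc1ccc(Nc2nc(SCc3ccc(C(F)(F)F)cc3)nc3ccccc23)cc1` differs from compound 1 by 4-methoxyphenyl in place of octyl on a nitrogen on an aromatic ring. For the measured compounds named here, the closest measured step is the one from compound 1 to compound 3, where 2-methoxyphenyl took the place of octyl on a nitrogen on an aromatic ring and only the limit remained. The same outcome is expected here. The step of a 2.3-fold higher number from compound 1 to compound 4 (0.36 log units; beyond the scatter) is expected to run toward a higher number, most likely beyond the limit. Compound 4 is therefore estimated at 60000 nM in this assay, within 25000 nM to 150000 nM.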

Compound 4, half-maximal inhibitory concentration: 47200 nM
Compound 4: the middle estimate sits 1.3-fold (0.10 log units) above what was measured; measured number inside the range.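

In this assay, 4-methoxyphenyl on the nitrogen gives a measured number where 2-methoxyphenyl left only a limit, so an aromatic ring at this place does not by itself end in a limit. Exchanging octyl for 4-methoxyphenyl gives a 1.8-fold higher number from compound 1 to compound 4 (0.26 log units; within the scatter), so these two groups are not separated here, although one is a chain and the other a ring. The comparisons with the other two compounds, an at least 1.0-fold lower number from compound 3 to compound 4 (0.02 log units; that floor lies within the scatter) and an at least 1.0-fold lower number from compound 2 to compound 4 (0.02 log units; that floor lies within the scatter), are floors only, and neither exchange has a readable size, since both start from a limit: the limit of > 50000 nM in this assay, at which 2 of the 4 values shown sit.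

On these data alone, it remains open whether a shorter chain such as butyl, or an aminoalkyl chain, on this nitrogen would give a clearly lower number. As far as these compounds go, the effect of replacing the trifluoromethyl group on the benzyl side with, for example, a nitrile also remains open.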